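The source may report more compounds than this note shows. Statements on the series, on what has been measured and on what is new or still open speak of the compounds shown alone.

Of the compounds shown here, two have been measured in a functional assay on PC-12 cells (Rattus norvegicus) for cytotoxicity, read by MTT assay, with stated times of 2 h and 24 h, tested at 10 uM; a higher number here means a stronger effect of the compound at the concentration tested, a lower number a weaker effect. Compound 1, `CC(C)(C)c1ccc(-n2nc(-c3ccc(C(F)(F)F)cc3O)nc2-c2ccccc2O)cc1`, gives 81.1%. Compound 2, `Oc1cc(C(F)(F)F)ccc1-c1nc(-c2ccccc2O)n(-c2ccc(I)cc2)n1`, gives 105%. Among the compounds with values here, the one step between them, a number 23.9 percentage points higher from compound 1 to compound 2 (beyond the scatter), is the only comparison available, and it places compound 2 at the higher of the two numbers, with compound 1 the lower.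

Compound 3, `Oc1cc(C(F)(F)F)ccc1-c1nc(-c2ccccc2O)n(-c2ccc(C(F)(F)F)cc2)n1`, is made from compound 2 by a single change: trifluoromethyl in place of iodo on an aromatic carbon. Within the data shown here, no measured pair shows exactly this change, so the expectation rests on the one step that exists. That step swapped the same position between tert-butyl and iodo and moved the read-out by a modest amount beyond the scatter; it suggests that a group at this position can shift the activity, but it does not say whether trifluoromethyl will behave more like iodo or more like tert-butyl. With no closer guide, compound 3 is expected to sit near compound 2, and the step of a number 10 percentage points lower from compound 2 to compound 3 (within the scatter) is estimated to fall within the scatter or only just beyond it. Compound 3 is therefore estimated at 95%, within a range from 75% to 112%.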

Compound 3, a percentage reported as activity, at one concentration (the size of the read-out at that concentration, not a potency): 102%
Beside the measured number, compound 3's estimate is 7 percentage points below it; low and high end bracket the measured number.
By their numbers in this assay, from the lowest: compound 1; then compounds 3 and 2 (each within the scatter of the next).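

In this assay, the change from 4-iodophenyl to 4-(trifluoromethyl)phenyl gives a number 3 percentage points lower from compound 2 to compound 3 (within the scatter) and so cannot be told apart from no change at all, which means that, in this pair, trifluoromethyl can take the place of iodo without a readable shift in the number. The tert-butyl comparison now has a second partner, with a number 20.9 percentage points higher from compound 1 to compound 3 (beyond the scatter) adding to the earlier step, so the gap between tert-butyl and the other groups at this position no longer rests on iodo alone. Nothing measured here explains why compound 1 stands apart from the other two compounds.

The compounds shown vary only among tert-butyl, iodo and trifluoromethyl on this aromatic carbon, so it remains open how a group of another kind, such as an amine, a carboxylic acid or a longer chain, would read there. Each number also comes from a single tested concentration, so these compounds leave open how the read-out would change at other concentrations.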